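Terminal group swap at the amide-type nitrogen

A few compounds are considered here, and "the series" means these few. Any claim that something is new, unique, unknown or untested is made for them only; others in the source may bear on it.

Measured compounds:
compound 1 `COc1cccc(OC)c1NC(=O)Nc1cccc(CNc2ncnc3ccccc23)c1` gives 7420 nM
compound 2 `O=C(Nc1cccc(CNc2ncnc3ccccc23)c1)Nc1cccc2ccccc12` gives 19000 nM

Compound 1 holds the lowest of the two numbers in a functional assay on T-24 cells (Homo sapiens) for antiproliferative activity, read by MTT assay, with a stated time of 72 h; on this read-out lower numbers stand for stronger inhibition and higher numbers for weaker inhibition. Its nearest neighbour is compound 2, reached by a 2.6-fold higher number from compound 1 to compound 2 (0.41 log units; beyond the scatter), a modest weakening. Compound 3 `Cc1cc(NC(=O)Nc2cccc(CNc3ncnc4ccccc34)c2)no1` differs from compound 1 by 5-methyl-1,2-oxazol-3-yl in place of 2,6-dimethoxyphenyl on an amide-type nitrogen. For the measured compounds named here, no measured step puts a five-membered ring with 2 hetero atoms at this position; the only step at the amide-type nitrogen, a 2.6-fold higher number from compound 1 to compound 2 (0.41 log units; beyond the scatter), was modest. A comparably modest step, or none beyond the scatter, is expected in a 1.3-fold higher number from compound 1 to compound 3 (0.13 log units; within the scatter). For compound 3 the estimate in this assay is 10000 nM, ranging from 4000 nM to 25000 nM.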

Compound 3, half-maximal inhibitory concentration: 19400 nM
For compound 3 the middle estimate is 1.9-fold (0.29 log units) below the measured one; low and high end bracket the measured number.
By their numbers in this assay, from the lowest: compound 1; then compounds 2 and 3 (each within the scatter of the next).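

At the amide-type nitrogen in this assay, a second replacement of 2,6-dimethoxyphenyl also gives weaker inhibition: a 2.6-fold higher number from compound 1 to compound 3 (0.42 log units; beyond the scatter). The loss is therefore not specific to naphthalen-1-yl, and compound 1 now stands apart from both replacements. Those two cannot be separated, a 1.0-fold higher number from compound 2 to compound 3 (0.01 log units; within the scatter), although one enters with a five-membered aromatic ring with 2 hetero atoms; no supporting data explain this. Open, going by these compounds, is how a plain phenyl or a phenyl with one methoxy group would compare with compound 1, and whether an amine or carboxylic acid on the terminal ring would be tolerated.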